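The compounds below may be only part of what the source reports. "The series", "measured", "known", "first", "only" and "open" are said of these compounds alone.

Measured compounds in the series:
- compound 1 `CNc1nc(-c2ccccc2)nc2c1nnn2Cc1ccccc1Cl`: 191000000 nM
- compound 2 `FC(F)(F)c1ccccc1Cn1nnc2c(NC3CCCCC3)nc(-c3ccccc3)nc21`: 6800000 nM

Compound 1 carries the highest number of the two in an assay on isolated protein for binding affinity to adenosine receptor A1 (Bos taurus); on this read-out lower numbers stand for stronger inhibition and higher numbers for weaker inhibition; the nearest is compound 2, whose number is lower by an amount beyond the scatter. Among the measured compounds shown here, no step between these two is worked out here, since they differ in more than one place, so their two values are taken only as they stand.

Compound 3 `CCNc1nc(-c2ccccc2)nc2c1nnn2Cc1ccccc1Cl` is not yet measured in this assay. Against compound 1 the change is methyl in place of hydrogen on a saturated chain carbon bound to a nitrogen on an aromatic ring. For the measured compounds named here, no measured step of this kind exists, so the expected step of a 2.7-fold lower number from compound 1 to compound 3 (0.44 log units; beyond the scatter) is put as a small move towards a lower number, close to the edge of the scatter. Compound 3 is accordingly estimated at 70000000 nM, within 15000000 nM to 250000000 nM.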

Compound 3, inhibition constant: 463000000 nM
For compound 3 the middle estimate is 6.6-fold (0.82 log units) below the measured one; measured number above the stated range.
By their numbers in this assay, from the lowest: compound 2; then compound 1; then compound 3.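

In this assay, among the compounds shown here, going from methylamino to ethylamino gives the only single-place step (a 2.4-fold higher number from compound 1 to compound 3 (0.38 log units; beyond the scatter)), a modest one. This position therefore responds to one added methyl on the saturated chain carbon bound to the nitrogen on the aromatic ring, and the number moves up rather than down. Nothing measured at hand bears on the origin of this shift.

From the compounds shown here alone, a single step sets no trend, and whether a longer chain such as propylamino, a branched isopropylamino or a plain amino group would continue this move stays open. Also open, going by these compounds, is whether the step holds with the benzyl group of compound 2, which differs from compound 1 in more than one place, leaving its lower number unassigned to any one group.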